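Benzimidazole to pyridine: an expected gain in solubility

The compounds below may be only part of what the source reports. "The series", "measured", "known", "first", "only" and "open" are said of these compounds alone.

Compound 3 `Cc1cc(C)c(-c2nc3ccccc3[nH]2)cc1NC(=O)c1ccc(OCc2ccccn2)cc1` carries a benzimidazole on the shared core. In a physicochemical assay for solubility, at pH 7.4 (a higher number here means a more soluble compound, a lower number a less soluble compound), compound 3 gives only a limit, < 1000 nM, and not a number. That limit is the one noted in the limit of < 1000 nM in this assay, at which 1 of the 3 values shown sits. The two measured relatives stand higher: compound 1 `Cc1cc(Cl)c(-c2cn(C)cn2)cc1NC(=O)c1ccc(OCc2ccccn2)cc1` gives 20000 nM in this assay, and compound 2 `Cc1ccc(-c2nccn2C)cc1NC(=O)c1ccc(OCc2ccccn2)cc1` gives 192000 nM. For the measured compounds named here, no single-point step joins any of these three, so their values are simply set side by side.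

Compound 4 `Cc1cc(C)c(-c2ccccn2)cc1NC(=O)c1ccc(OCc2ccccn2)cc1` has not yet been measured. It differs from compound 3 by pyridin-2-yl in place of 1H-benzimidazol-2-yl on an aromatic carbon. Since compound 3 reaches only a limit in this assay, any measurable number for compound 4 would already mark a rise. The step from compound 3 to compound 4 is expected to be an increase beyond the usual scatter, an at least 8.0-fold higher number from compound 3 to compound 4 (0.90 log units; beyond the scatter). The estimated solubility of compound 4 is 8000 nM, with a likely range from 1500 nM to 40000 nM.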

Compound 4, solubility: < 1000 nM
Compound 4: no number, only a limit; the forecaster's own chance of this, stated with the estimate: 20%; at least 8.0-fold (0.90 log units) between middle value and limit.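

Compound 4, like compound 3, gives only a limit and not a number, so no step can be read between them: the limit of < 1000 nM in this assay, at which 2 of the 4 values shown sit.

The compounds shown leave open whether pyridin-2-yl in place of 1H-benzimidazol-2-yl changes the value at all in this assay.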